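Swapping a Chloro for Methoxy on a Pyrazole Carboxamide Series

The compounds below may be only part of what the source reports. "The series", "measured", "known", "first", "only" and "open" are said of these compounds alone.

Measured so far:
compound 1, `O=C(NCc1cn(Cc2ccc(F)cc2)nn1)c1cn(-c2ccccc2)nc1-c1ccc(Cl)cc1`, 2800 nM 
compound 2, `O=C(NCc1cn(Cc2ccc(Cl)cc2)nn1)c1cn(-c2ccccc2)nc1-c1ccc(Cl)cc1`, 470 nM 
compound 3, `COc1ccc(Cn2cc(CNC(=O)c3cn(-c4ccccc4)nc3-c3ccc(Cl)cc3)nn2)cc1`, 1400 nM 

All three compounds were tested in a functional assay on HeLa cells (Homo sapiens) for antiproliferative activity, read by sulforhodamine B assay, with a stated time of 48 h; on this read-out higher numbers stand for weaker inhibition of growth and lower numbers for stronger inhibition of growth. Compound 2 and compound 1 share a core; how they differ is fluoro in place of chloro on an aromatic carbon. Read in the other direction, that change gives a 6.0-fold lower number from compound 1 to compound 2 (0.78 log units; beyond the scatter). Compound 3 carries a methoxy where compound 2 carries a chloro; the counted difference is methoxy in place of chloro on an aromatic carbon, and the step is a 3.0-fold higher number from compound 2 to compound 3 (0.47 log units; beyond the scatter). Between compound 1 and compound 3 the step is a 2.0-fold lower number from compound 1 to compound 3 (0.30 log units; within the scatter).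

Compound 4, `COc1ccc(-c2nn(-c3ccccc3)cc2C(=O)NCc2cn(Cc3ccc(F)cc3)nn2)cc1`, has not yet been measured in this assay. It differs from compound 1 by methoxy in place of chloro on an aromatic carbon. This is the same change as from compound 2 to compound 3, and its place reads the same; cut one bond further out, however, it reads only 4-chlorophenyl to 4-methoxyphenyl, whereas the earlier one also reads 4-chlorobenzyl to 4-methoxybenzyl, so the methoxy enters a different ring of the shared core.

Among the compounds with values here, the expected step is a 2.1-fold higher number from compound 1 to compound 4 (0.33 log units; beyond the scatter), resting on the one earlier example of this change, because a 3.0-fold higher number from compound 2 to compound 3 (0.47 log units; beyond the scatter) ran toward a higher number. Within the data shown here, with only one precedent on another ring, the range is kept wide. Compound 4 is estimated at 6000 nM, between 2000 nM and 20000 nM.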

Compound 4, concentration for 50% growth inhibition: 500 nM
Compound 4: middle estimate off by 12-fold (1.08 log units), on the high side; measured number below the stated range.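

In this assay, changing 4-chlorophenyl to 4-methoxyphenyl on the core of compound 1 gives a 5.6-fold lower number from compound 1 to compound 4 (0.75 log units; beyond the scatter), so growth inhibition became stronger with this swap, not weaker as the earlier swap had suggested. Methoxy in place of chloro therefore cannot be carried as a fixed step from one part of this series to another, since the two examples run in opposite directions and lie well apart: the same change on two cores in this assay, a 3.0-fold higher number (0.47 log units; beyond the scatter) from compound 2 to compound 3 and a 5.6-fold lower number (0.75 log units; beyond the scatter) from compound 1 to compound 4, 17-fold (1.22 log units) apart, beyond the scatter of two such steps. This does not show why they part, as each direction rests on a single pair of compounds, the methoxy enters a different ring of the shared core in each pair, and the group held constant on the rest of the molecule also differs, so these influences cannot be separated here, nor can any general rule for either ring be drawn.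

The compounds shown leave open whether other groups at the place of this chloro, such as a hydroxyl, an amine or a carboxylic acid, would also give stronger inhibition of growth than the chloro does. They also leave open how a methoxy on the 4-methoxyphenyl ring would behave with a chloro, rather than a fluoro, on the other ring.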